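Back to the phenoxy form in the iodinated series

The source may report more compounds than this note shows. Statements on the series, on what has been measured and on what is new or still open speak of the compounds shown alone.

In an ADME assay on a cell-free system (plasma, Mus musculus) for metabolic stability, with a stated time of 24 h (on this read-out higher numbers stand for a more stable compound and lower numbers for a less stable compound), compound 2 `COC1=CC(=O)c2c(c(CSc3ccc(I)cc3)c(C)n2C)C1=O` gives > 97% as its reading, which is a limit of the assay and not a number. Compound 1 `COC1=CC(=O)c2c(c(COc3ccc(I)cc3)c(C)n2C)C1=O` gives 80% in this assay as its reading. The unmeasured compound 3 `COC1=CC(=O)c2c(c(COc3cccc(I)c3)c(C)n2C)C1=O` differs from compound 2 by 3-iodophenoxy in place of (4-iodophenyl)sulfanyl on a saturated chain carbon bound to an aromatic carbon with 3-iodophenoxy in place of (4-iodophenyl)sulfanyl on a saturated chain carbon bound to an aromatic carbon. Among the compounds with values here, the one measured step bearing on this is a number at least 17 percentage points higher from compound 1 to compound 2 (beyond the scatter) for (4-iodophenyl)sulfanyl in place of 4-iodophenoxy. Compound 3 returns to the phenoxy form of compound 1 (80%) but carries 3-iodophenoxy rather than 4-iodophenoxy, and no measurement covers that difference. A fall of similar size, beyond the scatter, is therefore expected in this assay as a number at least 17 percentage points lower from compound 2 to compound 3 (beyond the scatter) on this reasoning. For compound 3 the estimate is 80% as the expected reading, with an expected range of 66% to 93% around it.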

Compound 3, percent of the compound remaining in the plasma assay: 80%
Compound 3: the middle estimate sits on the measured number at the digits printed; measured number inside the range.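

In the plasma assay there is no change at the digits printed from compound 1 to compound 3 (within the scatter), for 3-iodophenyl in place of 4-iodophenyl on an oxygen on a saturated carbon, so this change leaves the reading unmoved in the phenoxy form. In the plasma assay the gap between the sulfanyl and phenoxy forms now holds for both iodophenoxy compounds, with a number at least 17 percentage points lower from compound 2 to compound 3 (beyond the scatter). In a physicochemical assay, in phosphate buffer, with a stated time of 24 h, at pH 7.4 (a higher number here means that more of the compound is left, a lower number that less of the compound is left), compound 2 gives > 90%, which is a limit of the assay and not a number. In the physicochemical assay compound 3 gives > 90%, which is also a limit of the assay and not a number. In the physicochemical assay the step from compound 2 to compound 3 cannot be read: the limit of > 90% in the physicochemical assay, at which 2 of the 2 values shown sit.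

The compounds shown leave open whether a (3-iodophenyl)sulfanyl form would read like compound 2 in the plasma assay. Also open, going by these compounds, is how an amine or a carboxylic acid in place of the iodine, or a longer chain in place of the saturated chain carbon, would read in the plasma assay.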